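A few compounds are considered here, and "the series" means these few. Any claim that something is new, unique, unknown or untested is made for them only; others in the source may bear on it.

Compound 1: `Cn1c(-c2ccc(NC(=O)CCl)cc2)nc(-c2ccccc2)c1-c1ccccc1`; in a functional assay on MCF7 cells (Homo sapiens) for cytotoxicity, read by MTT assay, with a stated time of 24 h, tested at 16 ug/mL (on this read-out lower numbers stand for a weaker effect and higher numbers for a stronger effect at the one concentration tested), compound 1 gives 15.2%.
Compound 2: `Cc1ccc2oc(SCC(=O)Nc3ccc(-c4nc(-c5ccccc5)c(-c5ccccc5)n4C)cc3)nc2c1`; in this assay compound 2 gives 40.3%.

Among the compounds with values here, compound 2 holds the higher of the two numbers measured so far, with compound 1 the only other point. The single step shown, a number 25.1 percentage points higher from compound 1 to compound 2 (beyond the scatter), raised the read-out when the sulfanyl-linked ring was introduced. Compound 3, `Cn1ccnc1SCC(=O)Nc1ccc(-c2nc(-c3ccccc3)c(-c3ccccc3)n2C)cc1`, differs from compound 2 by 1-methyl-1H-imidazol-2-yl in place of 5-methyl-1,3-benzoxazol-2-yl on a sulfur. Within the data shown here, no measured step covers an exchange between two such rings, so only a modest downward drift beyond the scatter is expected. Compound 3 is estimated at 28%, between 12% and 45%. That estimate means a step of a number 12.3 percentage points lower from compound 2 to compound 3 (beyond the scatter).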

Compound 3, a percentage reported as activity, at one concentration (the size of the read-out at that concentration, not a potency): 32.4%
Compound 3: middle estimate off by 4.4 percentage points, on the low side; the measured number falls inside the stated range.
By their numbers in this assay, from the lowest: compound 1; then compounds 3 and 2 (each within the scatter of the next).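

In this assay the exchange of 5-methyl-1,3-benzoxazol-2-yl for 1-methyl-1H-imidazol-2-yl on the sulfur gives a number 7.9 percentage points lower from compound 2 to compound 3 (within the scatter), so this read-out does not separate the two groups, although the entering one has fewer heavy atoms and no six-membered ring. Replacing chloro with (1-methyl-1H-imidazol-2-yl)sulfanyl gives a number 17.2 percentage points higher from compound 1 to compound 3 (beyond the scatter), so a second sulfanyl-linked ring also stands clear of the chloro compound. Nothing at hand explains these numbers.

From the compounds shown here alone, whether an amine in place of the sulfur would hold the read-out at this level remains open. So does whether a plain phenyl or a short alkyl chain on the sulfur would serve as well as these rings.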